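The compounds below may be only part of what the source reports. "The series", "measured", "known", "first", "only" and "open" are said of these compounds alone.

Compound 1, `O=c1[nH]cnc2c1c(-c1cc3ccccc3o1)cn2[C@@H]1O[C@H](CO)[C@@H](O)[C@H]1O`: in a functional assay on CEM-DNR-bulk cells (Homo sapiens), read by MTT assay, with a stated time of 72 h (a higher number here means a weaker inhibitor, a lower number a stronger inhibitor), compound 1 gives > 20000 nM, a limit of the assay rather than a number.
Compound 2, `Nc1nc2c(c(-c3ccsc3)cn2[C@@H]2O[C@H](CO)[C@@H](O)[C@H]2O)c(=O)[nH]1`: compound 2 gives > 20000 nM, again a limit.
Compound 3, `Nc1nc2c(c(-c3ccoc3)cn2[C@@H]2O[C@H](CO)[C@@H](O)[C@H]2O)c(=O)[nH]1`: compound 3 gives 15000 nM.

Within the data shown here, compound 3 thus stands as the only compound with a real number in this assay; the other two values are limits, as the limit of > 20000 nM in this assay, at which 2 of the 3 values shown sit, records. Among the measured compounds shown here, the one measured step, an at least 1.3-fold lower number from compound 2 to compound 3 (0.12 log units; that floor lies within the scatter), leaves compound 3 at best slightly stronger than compound 2, and the gap lies within the scatter.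

Compound 4, `Nc1nc2c(c(-c3cc4ccccc4o3)cn2[C@@H]2O[C@H](CO)[C@@H](O)[C@H]2O)c(=O)[nH]1`, is not yet measured. It differs from compound 3 in one place: 1-benzofuran-2-yl in place of furan-3-yl on an aromatic carbon. For the measured compounds named here, no measured step covers this change directly. Compound 1 carries the same 1-benzofuran-2-yl group on a different core and shows only a limit, so nothing suggests a gain. The account therefore expects compound 4 to come out no stronger than compound 3, with a fair chance of another limit. The estimated step of a 1.5-fold higher number from compound 3 to compound 4 (0.17 log units; within the scatter) points toward a weaker inhibitor or no change beyond the scatter. Compound 4 is estimated at 22000 nM, between 6000 nM and 70000 nM.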

Compound 4, half-maximal inhibitory concentration: > 20000 nM
Compound 4: a limit, no number; the forecaster's own chance of this, stated with the estimate: 60%; the middle value is on the limit's open side.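

Putting 1-benzofuran-2-yl in place of furan-3-yl on this aromatic carbon gives an at least 1.3-fold higher number from compound 3 to compound 4 (0.12 log units; that floor lies within the scatter) in this assay, so the larger group brings no gain, although this floor alone does not establish a loss. Compound 1 showed this group only on a core without the amino group, whereas compound 4 shows that with the amino group present the result is again a limit; the steps to compound 4 from compound 1 and compound 2 cannot be read, as both ends of each are limits. Only compound 3 still has a real number, and the set now sits mostly at the edge of what this assay records: the limit of > 20000 nM in this assay, at which 3 of the 4 values shown sit.

For compound 3 the number is 15000 nM and the compounds shown leave open whether any group at this place can bring it well below that. They also leave open how compound 1, compound 2 and compound 4 truly compare beyond their limits. Nor do they show what an amine, a carboxylic acid or a plain phenyl ring would do on this aromatic carbon of the shared core.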